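A few compounds are considered here, and "the series" means these few. Any claim that something is new, unique, unknown or untested is made for them only; others in the source may bear on it.

Measured in a functional assay on HeLa cells (Homo sapiens) for antiproliferative activity, read by MTT assay, with a stated time of 48 h; on this read-out higher numbers stand for weaker inhibition and lower numbers for stronger inhibition:
Compound 1 `COc1ccc(N(C)c2ccnc(Cl)n2)cc1F`: 241 nM
Compound 2 `COc1ccc(N(C)c2ccnc(Cl)n2)cc1Cl`: 517 nM
Compound 3 `COc1ccc(N(C)c2ccnc(Cl)n2)cc1[N+](=O)[O-]`: 4730 nM

Compound 1 has the lowest number of the three, and the other two lie beyond the scatter from it. Compound 4 `COc1ccc(N(C)c2ccnc(Cl)n2)cc1OCCBr` has not yet been measured. It keeps the core of compound 1 but carries 2-bromoethoxy in place of fluoro on an aromatic carbon.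

Two measured steps replace that same fluoro group. The chloro replacement gives a 2.1-fold higher number from compound 1 to compound 2 (0.33 log units; beyond the scatter), a modest step, and the nitro replacement gives a 20-fold higher number from compound 1 to compound 3 (1.29 log units; beyond the scatter), a large one. Both point towards weaker inhibition, but neither replacement is an ether chain, so they offer only a loose guide. A step to a higher number in this assay, of a size between these two, is therefore expected, and the estimated step is a 6.2-fold higher number from compound 1 to compound 4 (0.79 log units; beyond the scatter). For compound 4 the estimated value is 1500 nM, with an expected range of 400 nM to 6000 nM.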

Compound 4, half-maximal inhibitory concentration: 3310 nM
For compound 4 the middle estimate is 2.2-fold (0.34 log units) below the measured one, within the range that was stated.
By their numbers in this assay, from the lowest: compound 1; then compound 2; then compounds 4 and 3 (each within the scatter of the next).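

In this assay, the position ortho to a methoxy group now carries a chain rather than a halogen or a nitro group, and 2-bromoethoxy gives a 14-fold higher number from compound 1 to compound 4 (1.14 log units; beyond the scatter) and a 6.4-fold higher number from compound 2 to compound 4 (0.81 log units; beyond the scatter) in the same direction. Set against the nitro group, it gives a 1.4-fold lower number from compound 3 to compound 4 (0.16 log units; within the scatter) and lies within the scatter, so this read-out does not separate these two quite different replacements, while fluoro keeps the lowest number of the four. Nothing measured here gives a reason for these steps.

The compounds shown leave open whether the higher number goes with the bromine or with the ether chain itself, which a plain ethoxy group or a 2-aminoethoxy chain would help to settle. They also leave open whether a longer chain ending in bromine would move the number further from that of compound 1.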